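This account rests on a few compounds, and the source may have more. Where it says the series, first, only, none or still open, it means among the compounds named here.

In an ADME assay on MT4 cells (Homo sapiens) for cytotoxicity, read by MTT assay, with a stated time of 4 days (a higher number here means that more compound is tolerated, a lower number that less compound is tolerated), two compounds have been measured so far. Compound 1 (`Cc1cc(C#N)cc(C)c1Oc1ccnc(SCC(=O)Nc2ccc(C#N)cc2)n1`) reads > 300000 nM, which is a limit of the assay and not a number. Compound 2 (`Cc1ccc(NC(=O)CS(=O)(=O)c2nccc(Oc3c(C)cc(C#N)cc3C)n2)cc1C`) gives 13900 nM, the only actual number shown. Compound 3 (`Cc1cc(C#N)cc(C)c1Oc1ccnc(S(=O)(=O)CC(=O)Nc2ccc(F)cc2)n1`) differs from compound 2 in one place: 4-fluorophenyl in place of 3,4-dimethylphenyl on an amide-type nitrogen, with 4-fluorophenyl in place of 3,4-dimethylphenyl on an amide-type nitrogen. Among the measured compounds shown here, no measured step covers this change, so only a modest shift towards more compound being tolerated in this assay is expected, a 2.2-fold higher number from compound 2 to compound 3 (0.33 log units; beyond the scatter). For compound 3 the estimated value is 30000 nM, with an expected range of 10000 nM to 100000 nM.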

Compound 3, half-maximal cytotoxic concentration: 26100 nM
The estimate for compound 3 lay 1.1-fold (0.06 log units) above the measured number; measured number inside the range.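

In this assay, 4-fluorophenyl in place of 3,4-dimethylphenyl on the amide-type nitrogen gives a 1.9-fold higher number from compound 2 to compound 3 (0.27 log units; within the scatter). Among the compounds shown here, this is the first step read at this position, and it shows that these two phenyl groups cannot be told apart here. Nothing measured here speaks to a cause for this step. Going by these compounds, whether a cyclohexyl group or a phenyl ring carrying an amine would read alike at this nitrogen remains open. Compound 1 gives > 300000 nM, which is a limit of the assay and not a number.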